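Amino for methylsulfanyl on a deoxyribosyl purine core

The source may report more compounds than this note shows. Statements on the series, on what has been measured and on what is new or still open speak of the compounds shown alone.

The account follows compound 1 `CSc1nc(SC)c2ncn([C@@H]3C[C@@H](O)[C@H](CO)O3)c2n1` to compound 4 `CSc1nc(N)c2ncn([C@@H]3C[C@@H](O)[C@H](CO)O3)c2n1`. In a functional assay on K562 cells (Homo sapiens) (on this read-out higher numbers stand for weaker inhibition and lower numbers for stronger inhibition), compound 1 reaches only the limit > 300 uM, so no number is known for it. Two related compounds help place it. Compound 2 `CNc1nc(Br)nc2c1ncn2[C@@H]1C[C@@H](O)[C@H](CO)O1` gives 110 uM. Compound 3 `CN(C)c1nc(Br)nc2c1ncn2[C@@H]1C[C@@H](O)[C@H](CO)O1` also stops at a limit, > 300 uM. Among the measured compounds shown here, the one measured step, an at least 2.7-fold higher number from compound 2 to compound 3 (0.43 log units; beyond the scatter), comes with methyl in place of hydrogen on a nitrogen on an aromatic ring, and it shares the limit of > 300 uM in this assay, at which 2 of the 3 values shown sit, with compound 1. The change now considered is amino in place of methylsulfanyl on an aromatic carbon. For the measured compounds named here, no measured step tests this exchange directly; the only guide is that compound 2, which keeps a hydrogen on its ring nitrogen, yields a number while compound 3 and compound 1 do not. A modest move to a measurable number is therefore expected, though a limit remains possible. Compound 4 is estimated at 150 uM, within 40 uM to 600 uM. The expected step is an at least 2.0-fold lower number from compound 1 to compound 4 (0.30 log units; that floor lies within the scatter).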

Compound 4, concentration for 50% inhibition: > 300 uM
Compound 4: a limit, no number; the forecaster's own chance of this, stated with the estimate: 40%; middle value at least 2.0-fold (0.30 log units) away from the limit.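

In this assay compound 4 gives > 300 uM, a limit and not a number. Compound 1 also gives only a limit, so no step between compound 1 and compound 4 can be read: the limit of > 300 uM in this assay, at which 3 of the 4 values shown sit. The compounds shown leave open whether amino in place of methylsulfanyl changes inhibition at all.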